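This account rests on a few compounds, and the source may have more. Where it says the series, first, only, none or still open, it means among the compounds named here.

Compound 1 `CC(=O)Nc1ccc2oc(-c3ccccc3F)cc(=O)c2c1` gives 205000 nM in an ADME assay on MT4 cells (Homo sapiens) for cytotoxicity, read by MTT assay, with a stated time of 4 days; on this read-out higher numbers stand for lower toxicity in this test and lower numbers for higher toxicity in this test. Compound 2 `CC(=O)Nc1ccc2oc(-c3cccc(F)c3)cc(=O)c2c1` gives 240000 nM in this assay. The change between them, (3-fluorophenyl in place of 2-fluorophenyl on an aromatic carbon), made the step of a 1.2-fold higher number from compound 1 to compound 2 (0.07 log units; within the scatter). Compound 3 `COc1c(-c2ccccc2F)oc2ccc(NC(C)=O)cc2c1=O` gives 180000 nM in this assay; its core differs from that of compound 1 by methoxy in place of hydrogen on an aromatic carbon, and the step was a 1.1-fold lower number from compound 1 to compound 3 (0.06 log units; within the scatter). Compound 4 `COc1c(-c2cccc(F)c2)oc2ccc(NC(C)=O)cc2c1=O` is not yet measured. It differs from compound 3 by 3-fluorophenyl in place of 2-fluorophenyl on an aromatic carbon, the same kind of change as from compound 1 to compound 2; here the place is ortho to a methoxy group, which the earlier place was not. Beside the step from compound 1 to compound 2, the step from compound 3 to compound 4 is expected to be a 1.2-fold higher number from compound 3 to compound 4 (0.07 log units; within the scatter), resting on that single earlier step. Compound 4 is therefore estimated at 210000 nM, between 130000 nM and 330000 nM.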

Compound 4, half-maximal cytotoxic concentration: 210000 nM
The estimate for compound 4 equals the measured number at the digits printed; low and high end bracket the measured number.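

In this assay, 3-fluorophenyl in place of 2-fluorophenyl gives a 1.2-fold higher number from compound 3 to compound 4 (0.07 log units; within the scatter), in line with the earlier step on the core of compound 1: the same change on two cores in this assay, a 1.2-fold higher number (0.07 log units; within the scatter) from compound 1 to compound 2 and a 1.2-fold higher number (0.07 log units; within the scatter) from compound 3 to compound 4, 1.0-fold (0.00 log units) apart, within the scatter of two such steps. Methoxy in place of hydrogen reads alike with either fluorophenyl group, giving a 1.1-fold lower number from compound 2 to compound 4 (0.06 log units; within the scatter): the same change on two cores in this assay, a 1.1-fold lower number (0.06 log units; within the scatter) from compound 1 to compound 3 and a 1.1-fold lower number (0.06 log units; within the scatter) from compound 2 to compound 4, 1.0-fold (0.00 log units) apart, within the scatter of two such steps. Going by these compounds alone, as every step here lies within the scatter, the agreement shows only that neither change shifts this read-out measurably across these four compounds; it does not show that an effect of fixed size carries from one core to another.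

On these data alone, it remains open whether the two changes would still combine this way where a step exceeds the scatter. An amine or a carboxylic acid in place of fluorine, or a longer chain in place of methoxy, could test this.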